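This account rests on a few compounds, and the source may have more. Where it says the series, first, only, none or still open, it means among the compounds named here.

Compound 1 `CC1(C)[C@H]2CC[C@]1(C)N(Cc1cn(-c3cccc(F)c3)nn1)C(=O)C2` gives 90 nM in a functional assay on LoVo cells (Homo sapiens) for inhibition, read by MTT assay, with a stated time of 24 h; on this read-out lower numbers stand for stronger inhibition and higher numbers for weaker inhibition. Compound 2 `CC1(C)[C@H]2CC[C@]1(C)N(Cc1cn(-c3cccc(C#N)c3)nn1)C(=O)C2` gives 320 nM. Compound 3 `CC1(C)[C@H]2CC[C@]1(C)N(Cc1cn(-c3ccc(F)cc3)nn1)C(=O)C2` gives 40 nM.

Compound 3 holds the lowest number of the three, and both the step of a 2.3-fold lower number from compound 1 to compound 3 (0.35 log units; beyond the scatter) and the step of an 8.0-fold lower number from compound 2 to compound 3 (0.90 log units; beyond the scatter) lie beyond the scatter. Compound 4 `CC1(C)[C@H]2CC[C@]1(C)N(Cc1cn(-c3cccc(O)c3)nn1)C(=O)C2` differs from compound 3 by 3-hydroxyphenyl in place of 4-fluorophenyl on an aromatic nitrogen. For the measured compounds named here, two measured steps bear on this change: a 2.3-fold lower number from compound 1 to compound 3 (0.35 log units; beyond the scatter) shows the 4-fluorophenyl outperforming the 3-fluorophenyl, and a 3.6-fold higher number from compound 1 to compound 2 (0.55 log units; beyond the scatter) shows that putting cyano in place of fluoro raised the number. Compound 4 is therefore expected to give a higher number than compound 3, a step of about a 5.0-fold higher number from compound 3 to compound 4 (0.70 log units; beyond the scatter). Compound 4 is estimated at 200 nM, with a range from 70 nM to 600 nM.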

Compound 4, half-maximal inhibitory concentration: 410 nM
For compound 4 the middle estimate is 2.1-fold (0.31 log units) below the measured one, within the range that was stated.
By their numbers in this assay, from the lowest: compound 3; then compound 1; then compounds 2 and 4 (each within the scatter of the next).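

The step of a 10-fold higher number from compound 3 to compound 4 (1.01 log units; beyond the scatter) changes both the group and where it sits on the phenyl ring, while a 4.6-fold higher number from compound 1 to compound 4 (0.66 log units; beyond the scatter) isolates hydroxy in place of fluoro and shows that this swap alone raises the number. Hydroxy and cyano cannot be told apart here, with a 1.3-fold higher number from compound 2 to compound 4 (0.11 log units; within the scatter), so both give higher numbers than fluoro on this carbon. Nothing available explains these differences.

As far as these compounds go, whether an amine or a methoxy group on this carbon would behave like hydroxy or like fluoro remains open. So does how hydroxy would fare in the place that fluoro holds in compound 3.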